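Replacing the Benzoyl Phenyl with Methyl in a Cytotoxic Amide

A few compounds are considered here, and "the series" means these few. Any claim that something is new, unique, unknown or untested is made for them only; others in the source may bear on it.

Measured in a functional assay on HL-60 cells (Homo sapiens) for cytotoxicity, read by MTT assay, with a stated time of 72 h; on this read-out lower numbers stand for stronger inhibition and higher numbers for weaker inhibition:
compound 1 `O=C(Nc1nnc(-c2cccc(O)c2O)s1)c1ccc(Cl)cc1`: 9600 nM
compound 2 `O=C(Nc1nnc(-c2cccc(O)c2O)s1)c1ccccc1`: 20700 nM

Of these two compounds, compound 2 gives the higher number, 20700 nM, and its nearest neighbour is compound 1 at 9600 nM. The next compound to be tested in this assay is compound 3 `CC(=O)Nc1nnc(-c2cccc(O)c2O)s1`. It departs from compound 2 by methyl in place of phenyl on a carbonyl carbon.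

Among the measured compounds shown here, only one measured step bears on this change: a 2.2-fold higher number from compound 1 to compound 2 (0.33 log units; beyond the scatter). That step is modest and lies beyond the scatter, and it comes from hydrogen in place of chloro on an aromatic carbon. It went towards weaker inhibition, but it only altered the aromatic ring, whereas compound 3 loses that ring altogether. For the measured compounds named here, no measured pair shows such a loss directly, so the guidance is weak. A modest upward step is therefore expected, no larger than the measured one, and a result level with compound 2 would not be surprising.

The expected change is a 1.7-fold higher number from compound 2 to compound 3 (0.23 log units; within the scatter). For compound 3 the estimated value is 35000 nM, with an expected range of 12000 nM to 90000 nM.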

Compound 3, half-maximal inhibitory concentration: 49000 nM
Estimate against measurement, compound 3: 1.4-fold (0.15 log units) below, and the stated range covers the measured number.
By their numbers in this assay, from the lowest: compound 1; then compound 2; then compound 3.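

In this assay, among the compounds shown here, the position on the carbonyl carbon proves open to direct change for the first time: the earlier pair altered only a substituent on the aromatic ring, whereas methyl in place of phenyl removes the ring itself and gives a 2.4-fold higher number from compound 2 to compound 3 (0.37 log units; beyond the scatter). Methyl in place of 4-chlorophenyl gives a 5.1-fold higher number from compound 1 to compound 3 (0.71 log units; beyond the scatter), so both the ring and its chloro substituent go with the lower numbers in this short series, and the order runs from compound 1 through compound 2 to compound 3. No measurement here explains why the loss of the ring weakens inhibition in these cells.

The three compounds cannot separate the presence of an aromatic ring from the mere size of the group on the carbonyl carbon, and a cyclohexyl group or a longer alkyl chain at that place would bear on this. As far as these compounds go, it also remains open whether the gain seen with chloro extends to other substituents on the ring, such as methoxy or a carboxylic acid.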